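Replacing the nitrile of compound 2 with a hydroxypropyl chain

A few compounds are considered here, and "the series" means these few. Any claim that something is new, unique, unknown or untested is made for them only; others in the source may bear on it.

compound 1 (`FC(F)(F)c1ccccc1-c1cc(Cl)c2[nH]c(C3=NOC4(CCCCC4)C3)nc2c1`): 3.3 nM in a functional assay on HEK293 cells for antagonist activity at transient receptor potential M8 protein (Canis lupus familiaris), read by FLIPR and calcium flux; on this read-out higher numbers stand for weaker inhibition and lower numbers for stronger inhibition
compound 2 (`N#Cc1cc(-c2ccccc2C(F)(F)F)cc2nc(C3=NOC4(CCCCC4)C3)[nH]c12`): 0.7 nM in this assay

Compound 2 holds the lowest of the two numbers in this assay; its nearest neighbour is compound 1, and the two are separated by a 4.7-fold lower number from compound 1 to compound 2 (0.67 log units; beyond the scatter). The step under consideration leads to compound 3 (`OCCCc1cc(-c2ccccc2C(F)(F)F)cc2nc(C3=NOC4(CCCCC4)C3)[nH]c12`), where the change is 3-hydroxypropyl in place of cyano on an aromatic carbon. For the measured compounds named here, no measured step involves a 3-hydroxypropyl group. Going by the values given here, the only step measured at this carbon is a 4.7-fold lower number from compound 1 to compound 2 (0.67 log units; beyond the scatter), which moved the number down when cyano took the place of chloro; it says nothing direct about the chain that now enters. Since the cyano that accompanied the lowest number is removed, compound 3 is expected to give a higher number, with an estimated step of a 7.1-fold higher number from compound 2 to compound 3 (0.85 log units; beyond the scatter). The estimate for compound 3 in this assay is 5 nM, expected to fall between 1 nM and 25 nM.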

Compound 3, half-maximal inhibitory concentration: 0.2 nM
Compound 3: middle estimate off by 25-fold (1.40 log units), on the high side; measured number below the stated range.
By their numbers in this assay, from the lowest: compound 3; then compound 2; then compound 1.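

In this assay, the cyano group is not needed for a low number at this aromatic carbon, since the step to the 3-hydroxypropyl chain gives a 3.5-fold lower number from compound 2 to compound 3 (0.54 log units; beyond the scatter) and the number falls further still. Measured against chloro at the same carbon, the chain gives a 17-fold lower number from compound 1 to compound 3 (1.22 log units; beyond the scatter) and so stands as the largest step seen at this position. The carbon therefore accepts a larger group that carries a hydrogen-bond donor, which cyano lacks, and both replacements of chloro lower the number, though nothing available explains why the chain does better than cyano.

The compounds shown leave open whether the hydroxyl or the propyl chain accounts for the step. A plain propyl group, a longer hydroxyalkyl chain, or an amine or carboxylic acid at the end of the chain would separate these possibilities.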